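From Pyridin-4-yl to 2-Chlorophenyl on the Carbonyl

This account rests on a few compounds, and the source may have more. Where it says the series, first, only, none or still open, it means among the compounds named here.

In an assay on brain for binding affinity to Voltage-gated L-type calcium channel (Rattus norvegicus) (on this read-out higher numbers stand for weaker inhibition and lower numbers for stronger inhibition), the measured compounds are:
compound 1 `CCOC(=O)[C@@H]1/C(=C/C(=O)c2ccncc2)N=C(C)/C(=C(/O)OCC)[C@H]1c1ccccc1C(F)(F)F` gives 25.5 nM
compound 2 `CCOC(=O)[C@@H]1C(/C=C(\O)c2ccccc2)=NC(C)=C([N+](=O)[O-])[C@H]1c1ccccc1C(F)(F)F` gives 336 nM
compound 3 `CCOC(=O)[C@@H]1C(C2=C(O)c3ccccc3CC2)=NC(C)=C(C#N)[C@H]1c1ccccc1C(F)(F)F` is reported only as a limit, > 1000 nM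

Compound 1 holds the lowest of the two actual numbers in this assay. Compound 2 sits at a higher number, a gap that lies beyond the usual scatter of repeated measurements. For compound 3 the assay gives no number at all, only a limit; this is the case described by the limit of > 1000 nM in this assay, at which 1 of the 3 values shown sits.

Compound 4 `CCOC(=O)[C@@H]1/C(=C/C(=O)c2ccccc2Cl)N=C(C)/C(=C(/O)OCC)[C@H]1c1ccccc1C(F)(F)F` is the next compound, not yet measured. It differs from compound 1 in a single place: 2-chlorophenyl in place of pyridin-4-yl on a carbonyl carbon. Going by the values given here, no measured pair among the compounds here shows this kind of change, so there is no directly comparable step to lean on. The change keeps the carbonyl and the rest of the shared core untouched, so the expectation is a step from compound 1 to compound 4 of a 1.3-fold lower number from compound 1 to compound 4 (0.11 log units; within the scatter), which is to say none beyond the scatter in either direction. Compound 4 is therefore estimated to give about 20 nM in this assay, with a likely range from 6 nM to 70 nM.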

Compound 4, half-maximal inhibitory concentration: > 1000 nM
Compound 4: no number, only a limit; the forecaster's own chance of this, stated with the estimate: 3%; middle value at least 50-fold (1.69 log units) from the limit.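

In this assay, the group on the carbonyl carbon matters a great deal: putting 2-chlorophenyl in place of pyridin-4-yl gives an at least 39-fold higher number from compound 1 to compound 4 (1.59 log units; beyond the scatter), with the rest of the molecule unchanged. The earlier compounds shown here differ from one another in more than one place, so none of them could single out this position, while this one change does. Compound 4 gives only a limit of the assay, > 1000 nM, so the true size of the step stays unknown, and such limits are not rare among these compounds: the limit of > 1000 nM in this assay, at which 2 of the 4 values shown sit.

The change removes the ring nitrogen and adds a chlorine at once, so the compounds shown cannot tell which of the two accounts for the step. They also leave open how this position would respond to other groups, such as an amine or a carboxylic acid on the aromatic ring.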